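Replacing (3,4-dichlorophenyl)amino with Phenyl in Compound 1

The compounds below may be only part of what the source reports. "The series", "measured", "known", "first", "only" and "open" are said of these compounds alone.

In a functional assay on NCI-H322M cells (Homo sapiens) for inhibition, read by sulforhodamine B assay, with a stated time of 48 h (on this read-out lower numbers stand for stronger inhibition of growth and higher numbers for weaker inhibition of growth), compound 1 (`COc1cc(-c2nn(-c3cccc(NC(=O)Nc4ccc(Cl)c(Cl)c4)c3)cc2-c2ccncc2)ccc1Cl`) gives 1690 nM. For the measured compounds named here, its only measured neighbour, compound 2 (`O=C(Nc1cccc(-n2cc(-c3ccncc3)c(-c3ccc(Cl)c(O)c3)n2)c1)Nc1ccc(Cl)c(Cl)c1`), gives 2890 nM. The gap is a 1.7-fold higher number from compound 1 to compound 2 (0.23 log units; within the scatter), which lies within the scatter, so neither compound ranks ahead of the other. That step puts hydrogen in place of methyl on an oxygen on an aromatic ring.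

Compound 3 (`COc1cc(-c2nn(-c3cccc(NC(=O)c4ccccc4)c3)cc2-c2ccncc2)ccc1Cl`) carries phenyl in place of (3,4-dichlorophenyl)amino on a carbonyl carbon. Going by the values given here, the one measured step concerns a different part of the molecule, so it gives no direct size for this change. Among the compounds with values here, both measured compounds carry the group that leaves, and no measured compound shows what happens without it. A modest weakening in this assay, meaning a higher number, is therefore a cautious expectation, although a step within the scatter remains possible. The expected change is a 2.4-fold higher number from compound 1 to compound 3 (0.37 log units; beyond the scatter). For compound 3 the estimated value is 4000 nM, with an expected range from 1200 nM to 15000 nM.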

Compound 3, concentration for 50% growth inhibition: 4590 nM
The estimate for compound 3 lay 1.1-fold (0.06 log units) below the measured number, and the stated range covers the measured number.
By their numbers in this assay, from the lowest: compounds 1, 2 and 3 (each within the scatter of the next, the first and the last beyond it).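

In this assay, for the compounds shown here, the change on this carbonyl carbon gives a 2.7-fold higher number from compound 1 to compound 3 (0.43 log units; beyond the scatter), the first step in this set that clears the scatter, so this position responds to a change in a way that can be told from noise. The response is modest: with benzamido in place of ((3,4-dichlorophenyl)carbamoyl)amino, compound 3 still has a measurable value of 4590 nM in this read-out, so growth inhibition does not vanish when the (3,4-dichlorophenyl)amino group leaves. Nothing available explains why the number rises, and the chlorine atoms and the nitrogen of the leaving group depart together, so this step cannot be assigned to either.

The compounds shown leave open which part of the group matters: phenylamino on the same carbonyl carbon would keep the nitrogen without the chlorine atoms, while 3,4-dichlorophenyl there would keep the chlorine atoms without the nitrogen. Also open, as far as these compounds go, is how this place responds to a group of a different kind, such as a morpholine ring or a longer chain like 2-phenylethyl.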